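Cytotoxicity of benzamide analogues: the dichloro step

The source may hold more compounds than are shown below. What is called first, only, known or untested is meant among the compounds shown, and "the series" means these compounds.

Compound 1 `Cc1cc(S(N)(=O)=O)ccc1NC(=O)COc1ccc(Cl)cc1NC(=O)c1ccccc1` gives the highest number of the three measured in a functional assay on C8166 cells (Homo sapiens) for cytotoxicity, read by MTT assay (a higher number here means that more compound is tolerated, a lower number that less compound is tolerated), at 207000 nM; compound 2 `Cc1cc(S(N)(=O)=O)ccc1NC(=O)COc1ccc(Cl)cc1NC(=O)c1cccc(Cl)c1` gives 59700 nM and compound 3 `Cc1cc(C)cc(C(=O)Nc2cc(Cl)ccc2OCC(=O)Nc2ccc(S(N)(=O)=O)cc2C)c1` gives 36500 nM. Compound 4 `Cc1cc(S(N)(=O)=O)ccc1NC(=O)COc1ccc(Cl)cc1NC(=O)c1ccc(Cl)cc1Cl` differs from compound 1 by 2,4-dichlorophenyl in place of phenyl on a carbonyl carbon. The step that bears on it is a 3.5-fold lower number from compound 1 to compound 2 (0.54 log units; beyond the scatter), a single chloro on the same ring; the step of a 5.7-fold lower number from compound 1 to compound 3 (0.75 log units; beyond the scatter), also on that ring, points the same way. Two chlorines are therefore expected to lower the number in this assay by a modest to moderate amount, beyond the scatter, in line with those steps. The estimate for compound 4 is 40000 nM, within 15000 nM to 110000 nM, an expected step of a 5.2-fold lower number from compound 1 to compound 4 (0.71 log units; beyond the scatter).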

Compound 4, half-maximal cytotoxic concentration: 61100 nM
For compound 4 the middle estimate is 1.5-fold (0.18 log units) below the measured one; measured number inside the range.
By their numbers in this assay, from the lowest: compounds 3, 2 and 4 (each within the scatter of the next); then compound 1.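

In this assay the 2,4-dichlorophenyl group on the carbonyl carbon gives a 3.4-fold lower number from compound 1 to compound 4 (0.53 log units; beyond the scatter) and so stays clearly apart from the unsubstituted phenyl. Set against the other substituted rings, it gives a 1.0-fold higher number from compound 2 to compound 4 (0.01 log units; within the scatter) and a 1.7-fold higher number from compound 3 to compound 4 (0.22 log units; within the scatter), both within the scatter. At this position, two chlorines in 2,4-dichlorophenyl therefore read the same as the single chlorine in 3-chlorophenyl, and all three substituted rings fall in one band.

From the compounds shown here alone, whether an amine or a carboxylic acid on this ring would leave that band stays open. No measured data here give a reason for the band.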